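The source may report more compounds than this note shows. Statements on the series, on what has been measured and on what is new or still open speak of the compounds shown alone.

Measured compounds in a functional assay on HL-60 cells (Homo sapiens) for antiproliferative activity, read by MTT assay, with a stated time of 48 h; a lower number here means a stronger inhibitor, a higher number a weaker inhibitor:
compound 1 `CN(C)CCCCn1c(N)c(-c2nc3ccccc3o2)c2nc(C#N)c(C#N)nc21` gives 640 nM
compound 2 `CCN(CC)CCCCn1c(N)c(-c2nc3ccccc3o2)c2nc(C#N)c(C#N)nc21` gives 450 nM
compound 3 `CN(C)CCCn1c(N)c(-c2nc3ccccc3n2C)c2nc(C#N)c(C#N)nc21` gives 2120 nM

Compound 1 and compound 2 share one core and differ only by diethylamino in place of dimethylamino on a saturated chain carbon, four bonds along the chain from an aromatic nitrogen. That step reads a 1.4-fold lower number from compound 1 to compound 2 (0.15 log units; within the scatter), so the two values cannot be ordered. Compound 3 carries a different core; the difference between the two cores is not broken down here. Its number stands beyond the scatter from both compound 1 and compound 2.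

Compound 4 `CCN(CC)CCCn1c(N)c(-c2nc3ccccc3n2C)c2nc(C#N)c(C#N)nc21` is not yet measured. It differs from compound 3 by diethylamino in place of dimethylamino on a saturated chain carbon, three bonds along the chain from an aromatic nitrogen. Among the measured compounds shown here, this is the same kind of change as the one from compound 1 to compound 2, though the place is not identical: there the amine sat four bonds along the chain from an aromatic nitrogen, here it sits three bonds along the chain from an aromatic nitrogen. For the measured compounds named here, with only one earlier instance of the change, and that one within the scatter, the expected step from compound 3 to compound 4 is a small one, a 1.3-fold lower number from compound 3 to compound 4 (0.12 log units; within the scatter), resting on compound 1 and compound 2 giving a 1.4-fold lower number from compound 1 to compound 2 (0.15 log units; within the scatter). Compound 4 is therefore expected to give about 1600 nM in this assay, with a range of 800 nM to 3200 nM.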

Compound 4, half-maximal inhibitory concentration: 2810 nM
Compound 4: the middle estimate sits 1.8-fold (0.24 log units) below what was measured; measured number inside the range.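

In this assay, diethylamino in place of dimethylamino gives a 1.3-fold higher number from compound 3 to compound 4 (0.12 log units; within the scatter), so the two values cannot be ordered. On the two cores, the change has no effect that can be told from the scatter, and the two steps cannot be told apart: the same change on two cores in this assay, a 1.4-fold lower number (0.15 log units; within the scatter) from compound 1 to compound 2 and a 1.3-fold higher number (0.12 log units; within the scatter) from compound 3 to compound 4, 1.9-fold (0.28 log units) apart, within the scatter of two such steps. Among the compounds shown here, this supports carrying the change between these two cores without expecting a readable shift in this assay, but it rests on only two pairs, in which the amine also sits at different places along the chain, and it does not show that the change would stay this small on any other core.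

The compounds shown leave open whether any change at this chain end can move the number beyond the scatter, for example a primary amine in place of either tertiary amine. They also leave open what a longer chain would do on the core of compound 3, and how much of the gap between the two cores belongs to the chain rather than to the core.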